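Swapping a Hydroxyazetidine for an Amide-Bearing Chain

A few compounds are considered here, and "the series" means these few. Any claim that something is new, unique, unknown or untested is made for them only; others in the source may bear on it.

Compound 1 `CN(C)S(=O)(=O)NC[C@@H]1CCCc2cc(S(=O)(=O)c3cccc(F)c3)ccc21`: 2 nM
Compound 2 `O=S(=O)(c1cccc(F)c1)c1ccc2c(c1)CCC[C@H]2CN1CCCS1(=O)=O`: 31.6 nM
Compound 3 `O=S(=O)(c1cccc(F)c1)c1ccc2c(c1)CCC[C@H]2CN1CC(O)C1`: 0.1 nM

All three share one core and differ only in the group on a saturated chain carbon bound to a saturated ring carbon. In an assay on isolated protein for displacement of a labelled ligand from 5-hydroxytryptamine receptor 6 (Homo sapiens) (on this read-out lower numbers stand for stronger inhibition and higher numbers for weaker inhibition), compound 3 gives the lowest number of the three: a 20-fold lower number from compound 1 to compound 3 (1.30 log units; beyond the scatter) and a 320-fold lower number from compound 2 to compound 3 (2.50 log units; beyond the scatter) both run toward it. Compound 4 `CNCC(=O)NC[C@@H]1CCCc2cc(S(=O)(=O)c3cccc(F)c3)ccc21` has (((methylamino)methyl)carbonyl)amino in place of 3-hydroxyazetidin-1-yl on a saturated chain carbon bound to a saturated ring carbon and has not yet been measured in this assay. The step that bears on it most is a 20-fold lower number from compound 1 to compound 3 (1.30 log units; beyond the scatter), since compound 1 also carries a group without a ring on that carbon; compound 2 shows that a ring alone does not secure a low number. Compound 4 is therefore expected to give 3 nM, within 0.5 nM to 20 nM, which means an expected 30-fold higher number from compound 3 to compound 4 (1.48 log units; beyond the scatter).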

Compound 4, inhibition constant: 0.159 nM
Compound 4: middle estimate off by 19-fold (1.28 log units), on the high side; the whole stated range lies above it.
By their numbers in this assay, from the lowest: compounds 3 and 4 (each within the scatter of the next); then compound 1; then compound 2.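

In this assay, a 1.6-fold higher number from compound 3 to compound 4 (0.20 log units; within the scatter), so the open chain (((methylamino)methyl)carbonyl)amino matches 3-hydroxyazetidin-1-yl on this carbon, and a ring is not needed for a number this low. What the chain carries also counts: with ((methylamino)methyl)carbonyl in place of dimethylsulfamoyl on the amine nitrogen, there is a 13-fold lower number from compound 1 to compound 4 (1.10 log units; beyond the scatter). The gap to the ring-bearing sulfonyl group is wider still, with a 200-fold lower number from compound 2 to compound 4 (2.30 log units; beyond the scatter).

Nothing given here explains why these groups differ. From the compounds shown here alone, whether a longer chain or a carboxylic acid on this carbon would keep such low numbers remains open.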